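Ester to acid at the chain end of the core

The source may report more compounds than this note shows. Statements on the series, on what has been measured and on what is new or still open speak of the compounds shown alone.

Compound 1 `CCOC(=O)CCCC/C=C(\c1ccccc1)c1cccnc1` is the starting point of this step. In an assay (Equus caballus) for inhibition of Thromboxane-A synthase (Homo sapiens), using microsomes (a higher number here means a weaker inhibitor, a lower number a stronger inhibitor), compound 1 gives 600 nM, the highest of the three numbers recorded so far. Compound 2 `O=C(O)C(CCC/C=C(\c1cccnc1)c1cccs1)c1ccccc1` gives 50 nM in this assay, and compound 3 `O=C(O)CCCC/C=C(\c1cccnc1)c1cccc([N+](=O)[O-])c1` gives 73 nM; both stand well below compound 1, beyond the scatter. None of these three pairs differs in a single place, so the gaps are noted as they stand and not read as steps.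

Compound 4 `COCC(CCC/C=C(\c1ccccc1)c1cccnc1)C(=O)O` has not been measured. It differs from compound 1 in one place: 1-carboxy-2-methoxyethyl in place of (ethoxycarbonyl)methyl on a saturated chain carbon, three bonds along the chain from a double-bonded chain carbon. The group that leaves carries no hydrogen-bond donor; the group that enters carries one.

Within the data shown here, a step toward lower numbers is expected from compound 1 to compound 4, a 7.5-fold lower number from compound 1 to compound 4 (0.88 log units; beyond the scatter), because compound 2 at 50 nM and compound 3 at 73 nM each carry a carboxy group like the one that enters in compound 4, and both sit far below compound 1. Among the measured compounds shown here, the size is uncertain, since no measured single-place step backs it. For compound 4 in this assay the estimate is 80 nM, with a range from 25 nM to 250 nM.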

Compound 4, half-maximal inhibitory concentration: 41 nM
The estimate for compound 4 lay 2.0-fold (0.29 log units) above the measured number; low and high end bracket the measured number.
By their numbers in this assay, from the lowest: compounds 4, 2 and 3 (each within the scatter of the next); then compound 1.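

Among these compounds, the step from the ester to the acid is the first single-place comparison: in this assay, 1-carboxy-2-methoxyethyl in place of (ethoxycarbonyl)methyl gives a 15-fold lower number from compound 1 to compound 4 (1.17 log units; beyond the scatter) on the core of compound 1. Among the compounds shown here, the gaps among the earlier compounds could not be tied to any one place, whereas this step ties a large change in the number to a saturated chain carbon, three bonds along the chain from a double-bonded chain carbon, with the rest of the structure held constant. No measurement on hand bears on why the step has this size.

For the compounds shown here, the group that enters differs from the group that leaves both in its carboxy group, which carries a hydrogen-bond donor, and in its methoxy-bearing branch, so the single step does not show how much of the change belongs to either feature. Also open, going by these compounds, is how a plain carboxymethyl group, a primary amide or a tetrazole would read in the same place on this core, and whether a longer chain would keep the lower number.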